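Trading the methylamino of compound 2 for an ester

A few compounds are considered here, and "the series" means these few. Any claim that something is new, unique, unknown or untested is made for them only; others in the source may bear on it.

The shared core of these compounds is seen in compound 1 `N#Cc1c(N)cccc1NC(=O)C(=O)O`, compound 2 `CNc1cccc(NC(=O)C(=O)O)c1C#N` and compound 3 `CC(C)Oc1cccc(NC(=O)C(=O)O)c1C#N`. In a functional assay on the whole organism for inhibition, with Rattus norvegicus as the target, at a dose of 1 mg/kg by the oral route (on this read-out lower numbers stand for less inhibition and higher numbers for more inhibition at the one dose given (going by the name of the read-out)), compound 1 gives 21.2%, compound 2 gives 96% and compound 3 gives 75.1%. Compound 2 thus stands highest of the three, with compound 3 nearest and compound 1 furthest behind. The measured steps are a number 74.8 percentage points higher from compound 1 to compound 2 (beyond the scatter), a number 53.9 percentage points higher from compound 1 to compound 3 (beyond the scatter) and a number 20.9 percentage points lower from compound 2 to compound 3 (beyond the scatter).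

Compound 4 `COC(=O)c1cccc(NC(=O)C(=O)O)c1C#N` has not yet been measured. Its change from compound 2 is methoxycarbonyl in place of methylamino on an aromatic carbon. The step most closely related is a number 20.9 percentage points lower from compound 2 to compound 3 (beyond the scatter), where the methylamino of compound 2 was likewise replaced, and that lost a modest amount. Compound 1, which also lacks the methylamino, sits far lower. A downward step is therefore expected in this assay, of uncertain size. Compound 4 is estimated at 60%, within 25% to 90%, which would mean a step of a number 36 percentage points lower from compound 2 to compound 4 (beyond the scatter).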

Compound 4, a percentage reported as inhibition, in the whole organism at one dose (the size of the read-out at that dose, not a potency): 24.5%
Compound 4: middle estimate off by 35.5 percentage points, on the high side; measured number outside the range, below it.
By their numbers in this assay, from the lowest: compounds 1 and 4 (each within the scatter of the next); then compound 3; then compound 2.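

In this assay, methoxycarbonyl on the aromatic carbon ortho to a cyano group gives a number 71.5 percentage points lower from compound 2 to compound 4 (beyond the scatter), and it also falls well short of isopropoxy, with a number 50.6 percentage points lower from compound 3 to compound 4 (beyond the scatter). The earlier compounds shown here showed that a group other than methylamino could keep much of the read-out at this position; this result shows that not every replacement does, and with a number 3.3 percentage points higher from compound 1 to compound 4 (within the scatter) the ester sits level with the amino group of compound 1. Nothing available here accounts for the difference between these groups.

An amide or a carboxylic acid at this position would show whether the loss goes with the carbonyl or with the ester as a whole. Ethylamino would show whether a longer chain on the nitrogen keeps the high number of compound 2.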